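Hydroxy for Methylamino: Expected Shift in Receptor Binding

The source may hold more compounds than are shown below. What is called first, only, known or untested is meant among the compounds shown, and "the series" means these compounds.

Of the compounds shown here, three sharing one core have been measured in an assay on isolated protein for binding affinity to corticotropin-releasing factor receptor 1 (Homo sapiens); a higher number here means a weaker inhibitor, a lower number a stronger inhibitor. Compound 1 `CCCN(Cc1ccccc1)c1cc(C)nc2c(-c3ncc(C(F)(F)F)cc3Cl)c(C)nn12` gives 1.7 nM in this assay. Compound 2 `CCCN(CC1CC1)c1cc(C)nc2c(-c3ncc(Cl)cc3Cl)c(C)nn12` gives 3.9 nM in this assay. Compound 3 `CCCN(CCC)c1cc(C)nc2c(-c3ncc(NC)cc3C)c(C)nn12` gives 40 nM in this assay, the highest of the three numbers; its gap to compound 2 and its larger gap to compound 1 both lie beyond the usual scatter of repeated measurements. No pair among these three differs in only one place, so no single-point step has been measured in this set.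

Compound 4 `CCCN(CCC)c1cc(C)nc2c(-c3ncc(O)cc3C)c(C)nn12` is not yet measured. It differs from compound 3 in one place: hydroxy in place of methylamino on an aromatic carbon. Among the compounds with values here, since no measured pair covers this change, the expectation rests on compound 3 alone and on the small size of the counted difference. A step toward a somewhat higher number, that is weaker binding, is expected in this assay, though it may turn out no larger than the scatter. Compound 4 is estimated at 70 nM, within a range from 20 nM to 300 nM. The change from compound 3 to compound 4 is expected to amount to a 1.8-fold higher number from compound 3 to compound 4 (0.24 log units; within the scatter).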

Compound 4, inhibition constant: 530 nM
Beside the measured number, compound 4's estimate is 7.6-fold (0.88 log units) below it, outside the stated range (above it).
By their numbers in this assay, from the lowest: compound 1; then compound 2; then compound 3; then compound 4.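

Within the data shown here, the first single-point step falls on this position: with hydroxy in place of methylamino on an aromatic carbon two atoms from the ring nitrogen, para to a large group, this assay records a 13-fold higher number from compound 3 to compound 4 (1.12 log units; beyond the scatter) for this one change. Methylamino leaves with 2 heavy atoms and hydroxy enters with 1, while the hydrogen-bond donor and acceptor counts are the same on both sides, so those counts do not separate the two groups, yet binding at this position clearly does. No measurement in hand bears on what lies behind the step.

Still open, from the compounds shown here alone, is whether the step follows from the oxygen itself or from the loss of the methyl on nitrogen: an unsubstituted amine, a dimethylamino group or a methoxy group at this position would separate those readings. Among these compounds, compounds 1 and 2 carry trifluoromethyl and chloro at this position but differ from compound 3 in other places too, so they give no single-point step here, and whether the loss seen with hydroxy would carry over to other side chains on the shared core also remains open.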